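The source may report more compounds than this note shows. Statements on the series, on what has been measured and on what is new or still open speak of the compounds shown alone.

Compound 1 `CC(C)=CCOc1cccc(O)c1C(=O)/C=C/c1ccc(O)cc1` was tested in a functional assay on MDA-MB-231 cells (Homo sapiens) for antiproliferative activity, read by sulforhodamine B assay; a higher number here means a weaker inhibitor of growth, a lower number a stronger inhibitor of growth. In this assay compound 1 gives only a limit, > 30000 nM. Compound 2 `CC(C)COc1cccc(O)c1C(=O)/C=C/c1ccc(O)cc1` differs from compound 1 in one place, and in this assay compound 2 gives 3520 nM. For the measured compounds named here, the single measured step is an at least 8.5-fold lower number from compound 1 to compound 2 (0.93 log units; beyond the scatter), and how large it really is rests on (the limit of > 30000 nM in this assay, at which 1 of the 2 values shown sits). Compound 3 `O=C(/C=C/c1ccc(O)cc1)c1c(O)cccc1OCCC1CCCC1` has not yet been measured. It differs from compound 1 by cyclopentylmethyl in place of 2-methylprop-1-en-1-yl on a saturated chain carbon bound to an oxygen on an aromatic ring. The measured step also trades the 2-methylprop-1-en-1-yl for a group without a double bond, so a move to a lower number is expected here as well, but the entering cyclopentylmethyl is larger than the isopropyl of compound 2, so the expectation is held loosely. Compound 3 is expected to give about 8000 nM, within a range from 2500 nM to 30000 nM. The expected step is an at least 3.7-fold lower number from compound 1 to compound 3 (0.57 log units; beyond the scatter).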

Compound 3, concentration for 50% growth inhibition: 3340 nM
Beside the measured number, compound 3's estimate is 2.4-fold (0.38 log units) above it; low and high end bracket the measured number.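

In this assay, a second group without a double bond also lowers the number at this saturated chain carbon bound to an oxygen on an aromatic ring: cyclopentylmethyl in place of 2-methylprop-1-en-1-yl gives an at least 8.9-fold lower number from compound 1 to compound 3 (0.95 log units; beyond the scatter). Swapping isopropyl for cyclopentylmethyl gives a 1.1-fold lower number from compound 2 to compound 3 (0.02 log units; within the scatter), so adding a ring here leaves the two compounds level, and this position accepts both the small branched group and the larger ring-bearing one. How large the steps away from compound 1 really are stays open, as compound 1 gives only a limit: the limit of > 30000 nM in this assay, at which 1 of the 3 values shown sits.

For the compounds shown here, only one group with a double bond appears here, so it remains open whether the double bond itself or that particular group accounts for the weak result. On these data alone, the effect of an amine, a carboxylic acid or a longer straight chain at this place also remains unknown.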